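The source may report more compounds than this note shows. Statements on the series, on what has been measured and on what is new or still open speak of the compounds shown alone.

In a functional assay on MGC-803 cells (Homo sapiens) for antiproliferative activity, read by MTT assay, with a stated time of 72 h (a lower number here means a stronger inhibitor, a higher number a weaker inhibitor), two compounds of the series have been measured so far: compound 1 (`O=C(NO)c1ccc(NCc2nc(-c3ccc(Cl)cc3)nn2-c2ccccc2)cc1`) gives 5970 nM and compound 2 (`O=C(NO)c1ccc(NCc2nc(-c3ccccc3)nn2-c2ccc(F)cc2)cc1`) gives 10500 nM. For the measured compounds named here, compound 1 therefore sits within the scatter of the only other measured compound, and the two values do not separate. Compound 3 (`Cc1cccc(-c2nc(CNc3ccc(C(=O)NO)cc3)n(-c3ccccc3)n2)c1`) keeps the rest of compound 1 and changes one group: 3-methylphenyl in place of 4-chlorophenyl on an aromatic carbon, with 3-methylphenyl in place of 4-chlorophenyl on an aromatic carbon. Going by the values given here, no measured pair isolates this change, so the expected level rests only on compound 1 at 5970 nM and compound 2 at 10500 nM. In this assay no step beyond the scatter is expected, in either direction. The expected step is a 1.2-fold higher number from compound 1 to compound 3 (0.07 log units; within the scatter). Compound 3 is estimated at 7000 nM, with an expected range of 2500 nM to 18000 nM.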

Compound 3, half-maximal inhibitory concentration: 8710 nM
The estimate for compound 3 lay 1.2-fold (0.09 log units) below the measured number; low and high end bracket the measured number.
By their numbers in this assay, from the lowest: compounds 1, 3 and 2 (each within the scatter of the next).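

On the aromatic carbon between two ring nitrogen atoms, 3-methylphenyl in place of 4-chlorophenyl gives a 1.5-fold higher number from compound 1 to compound 3 (0.16 log units; within the scatter) in this assay, the only step in the series shown that isolates a change at this position. The two groups have the same count of heavy atoms and each carries one six-membered aromatic ring of carbon only, yet they differ both in the substituent and in where it stands, and this single step cannot separate those two differences. No measurement available here bears on why the two values do not separate.

From the compounds shown here alone, it remains open whether a step beyond the scatter can be reached at this position at all. Replacing the aryl group with an amine or a carboxylic acid would test this beyond the phenyl groups shown.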